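A methyl step from compound 3 to compound 4

The compounds below may be only part of what the source reports. "The series", "measured", "known", "first", "only" and "open" are said of these compounds alone.

Measured so far in a functional assay on HL-60 cells (Homo sapiens) for cytotoxicity, read by WST assay, with a stated time of 48 h; a lower number here means that less compound is needed, a higher number that more compound is needed for the effect:
Compound 1 `COCOc1ccccc1C[C@H]1C(=O)OC[C@@H]1Cc1ccccc1` gives 76000 nM
Compound 2 `O=C1OC[C@H](Cc2ccccc2)[C@H]1Cc1cccc(Cl)c1` gives 36000 nM
Compound 3 `O=C1OC[C@H](Cc2ccccc2)[C@H]1Cc1ccc(Cl)c(Cl)c1` gives 19000 nM

Among these three, compound 3 lies within the scatter of compound 2, while the gap between compound 3 and compound 1 goes beyond the scatter, with compound 3 on the lower side. Compound 4 `Cc1cccc(C[C@H]2COC(=O)[C@@H]2Cc2ccc(Cl)c(Cl)c2)c1` departs from compound 3 through a single change, (methyl in place of hydrogen on an aromatic carbon), which is methyl in place of hydrogen on an aromatic carbon, or phenyl to 3-methylphenyl when cut one bond further out.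

Going by the values given here, only one measured step offers any guide. It is a 1.9-fold lower number from compound 2 to compound 3 (0.28 log units; within the scatter), with chloro in place of hydrogen on an aromatic carbon, and it stays within the scatter. Among the compounds with values here, no measured step shows methyl entering, so this comparison is a loose one. Going by the small size of that single step, no shift beyond the scatter is expected in this assay, and no firm direction can be given. The expected step is a 1.3-fold lower number from compound 3 to compound 4 (0.10 log units; within the scatter), a small one. For compound 4 the estimated value is 15000 nM, with an expected range from 6000 nM to 40000 nM.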

Compound 4, half-maximal effective concentration: 22000 nM
Beside the measured number, compound 4's estimate is 1.5-fold (0.17 log units) below it; measured number inside the range.
By their numbers in this assay, from the lowest: compounds 3, 4 and 2 (each within the scatter of the next); then compound 1.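

In this assay, exchanging phenyl for 3-methylphenyl gives a 1.2-fold higher number from compound 3 to compound 4 (0.06 log units; within the scatter), so at this aromatic carbon, meta to a large group, a single methyl in place of hydrogen leaves no effect that can be told apart from the scatter. Going by these compounds alone, the phenyl group carries no substituent in compound 1, compound 2 or compound 3, which means that compound 4 gives the only reading here for a substituent on that ring, whereas the earlier compounds differ only on the other aromatic ring. No measurement is available to explain why the methyl makes so little difference in this assay.

Going by these compounds, one methyl at one carbon says little about the rest of this ring, so it remains open whether the same small step would hold for a methyl on another carbon or for chloro, which sits on the other ring in compound 3. On these data alone, it also remains open whether a methoxy group, an amine, a carboxylic acid or a longer chain at this same carbon would stay within the scatter of compound 3 or move the number beyond it.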